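The source may report more compounds than this note shows. Statements on the series, on what has been measured and on what is new or still open speak of the compounds shown alone.

Measured in a physicochemical assay for acid dissociation, each a limit and not a number:
- compound 1 `O=C1C(Cl)=C(Nc2ccc(S(=O)(=O)Nc3nccs3)cc2)C(=O)c2ccccc21`: < 7.91
- compound 2 `O=C1C(Cl)=C(Nc2ccc(S(=O)(=O)Nc3cnn(-c4ccccc4)c3)cc2)C(=O)c2ccccc21`: < 7.91
- compound 3 `Cc1cc(C)nc(NS(=O)(=O)c2ccc(NC3=C(Cl)C(=O)c4ccccc4C3=O)cc2)n1`: < 7.91

Compound 3 has only a limit, < 7.91. It shares (the limit of < 7.91 in this assay, at which 3 of the 3 values shown sit).

Compound 4 `Cc1cc(NS(=O)(=O)c2ccc(NC3=C(Cl)C(=O)c4ccccc4C3=O)cc2)no1` carries one change: 5-methyl-1,2-oxazol-3-yl in place of 4,6-dimethylpyrimidin-2-yl on a sulfonamide nitrogen. In words, this is 5-methyl-1,2-oxazol-3-yl in place of 4,6-dimethylpyrimidin-2-yl on a sulfonamide nitrogen.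

Three measured changes at the same place bear on it: a step that the two limits leave unreadable from compound 1 to compound 2, a step that the two limits leave unreadable from compound 1 to compound 3 and a step that the two limits leave unreadable from compound 2 to compound 3. None of them has a size that can be read, so they give neither a size nor a direction to carry over. The working expectation is simply that compound 4 reports a limit in this assay as well, resting on the limit of compound 3 at < 7.91.

The expected step, a step that the limit leaves unreadable from compound 3 to compound 4, has no readable measured step behind it and remains a rough estimate. For compound 4 the estimated value is 7.3, with an expected range from 6 to 7.9.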

Compound 4, acid dissociation constant: < 7.91
Compound 4: only a limit was reported; the forecaster's own chance of this, stated with the estimate: 85%; the middle value lies beyond the limit too.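

In this assay compound 4 gives only a limit, < 7.91. Within the data shown here, no step linking compound 4 to compound 1, compound 2 or compound 3 can be read: the limit of < 7.91 in this assay, at which 4 of the 4 values shown sit. The compounds shown leave open the size and direction of any difference between these groups on the sulfonamide nitrogen.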